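Five-membered sulfur rings on the shared core: compound 4

This account rests on a few compounds, and the source may have more. Where it says the series, first, only, none or still open, it means among the compounds named here.

Measured so far in a functional assay for activation of Alpha-1D adrenergic receptor (Homo sapiens), read by calcium flux; on this read-out lower numbers stand for an effect already at smaller amounts and higher numbers for an effect only at larger amounts of compound:
compound 1 `c1cncc(-c2ccccc2OCC2=NCCN2)c1` gives 158 nM.
compound 3 `c1ccc(-c2ccsc2)c(OCC2=NCCN2)c1` gives 12.6 nM.
For compound 2 `c1cnc(-c2ccccc2OCC2=NCCN2)nc1` the result is only a limit, < 100000 nM.

Compound 2 thus stands without a readable number among the three compounds; the steps a step that the limit leaves unreadable from compound 1 to compound 2 and a step that the limit leaves unreadable from compound 2 to compound 3 cannot be sized, and all that can be said is that compound 2 is marked by the limit of < 100000 nM in this assay, at which 1 of the 3 values shown sits. Within the data shown here, the one readable step is a 13-fold lower number from compound 1 to compound 3 (1.10 log units; beyond the scatter), thiophen-3-yl in place of pyridin-3-yl on an aromatic carbon, and it is the only measured guide to a sulfur-containing five-membered aromatic ring on the shared core.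

Compound 4 `Cc1cc(-c2ccccc2OCC2=NCCN2)sn1` has not been measured. It differs from compound 2 by 3-methyl-1,2-thiazol-5-yl in place of pyrimidin-2-yl on an aromatic carbon. The entering 3-methyl-1,2-thiazol-5-yl is, like the thiophen-3-yl of compound 3, a five-membered aromatic ring containing sulfur, so compound 4 is expected to sit near compound 3 rather than near the limit of compound 2. Compound 4 is therefore estimated at 30 nM, with a range from 8 nM to 150 nM. The expected step that the limit leaves unreadable from compound 2 to compound 4 cannot be sized, since it starts from a limit.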

Compound 4, half-maximal effective concentration: < 100000 nM
Compound 4 gave a limit, no number; the forecaster's own chance of this, stated with the estimate: 10%; the middle value is on the limit's open side.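

In this assay compound 4 gives < 100000 nM, a limit and not a number. No step from compound 1, compound 2 or compound 3 to compound 4 can be read, and compound 4 joins compound 2 in this: the limit of < 100000 nM in this assay, at which 2 of the 4 values shown sit.

The compounds shown leave open how far compound 2 and compound 4 actually lie from compound 3.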